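The compounds below may be only part of what the source reports. "The series", "measured", "known", "first", "only" and "open" are said of these compounds alone.

For the measured compounds named here, in a functional assay on SK-LU-1 cells (Homo sapiens) for antiproliferative activity, read by sulforhodamine B assay, with a stated time of 48 h, tested at 50 uM (on this read-out higher numbers stand for more inhibition at the one concentration tested (going by the name of the read-out) and lower numbers for less inhibition), compound 3 `CC1=CC[C@H](C(C)C)c2cc(C)c(OC(=O)c3cccc(C(F)(F)F)c3)cc21` gives 18.3%, the lowest of the three numbers measured so far. Compound 1 `COc1cccc(C(=O)Oc2cc3c(cc2C)[C@@H](C(C)C)CC=C3C)c1` gives 24.2%, and the step of a number 5.9 percentage points lower from compound 1 to compound 3 (within the scatter) stays within the scatter. Compound 2 `CC1=CC[C@H](C(C)C)c2cc(C)c(OC(=O)Nc3ccccc3)cc21` gives 100%, and the step of a number 75.8 percentage points higher from compound 1 to compound 2 (beyond the scatter) is large, but it alters a different part of the molecule than the change now considered. Compound 4 `CC1=CC[C@H](C(C)C)c2cc(C)c(OC(=O)c3cccc([N+](=O)[O-])c3)cc21` differs from compound 3 by nitro in place of trifluoromethyl on an aromatic carbon. Going by the values given here, the only step of the same kind, an exchange of one small group on that aromatic carbon, produced no shift beyond the scatter, so a similar outcome is expected here. For compound 4 the estimated value in this assay is 22%, between 8% and 40%. The expected step is thus a number 3.7 percentage points higher from compound 3 to compound 4 (within the scatter).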

Compound 4, a percentage reported as inhibition, at one concentration (the size of the read-out at that concentration, not a potency): 60.4%
Compound 4: middle estimate off by 38.4 percentage points, on the low side; the whole stated range lies below it.
By their numbers in this assay, from the lowest: compounds 3 and 1 (each within the scatter of the next); then compound 4; then compound 2.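

In this assay this aromatic carbon turns out to be sensitive to which small group it carries: there is a number 42.1 percentage points higher from compound 3 to compound 4 (beyond the scatter) and also a number 36.2 percentage points higher from compound 1 to compound 4 (beyond the scatter) when nitro comes in. Nitro therefore stands apart from trifluoromethyl and methoxy, whose values lie within the scatter of each other. Replacing the whole aryl group on the carbonyl carbon also counts, with a number 39.6 percentage points lower from compound 2 to compound 4 (beyond the scatter) for 3-nitrophenyl in place of anilino. On these data alone, it remains open whether an amine or a nitrile on this carbon would behave like nitro or like trifluoromethyl. The data at hand give no reason for the jump with nitro.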